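The source may report more compounds than this note shows. Statements on the series, on what has been measured and on what is new or still open speak of the compounds shown alone.

Working notes on the series.

Of the compounds shown here, two carry numbers so far. Compound 1 `COc1c(/C=C2/C(=O)Nc3ccccc32)c2ccccc2n1-c1ccccc1` is the simpler member; in a functional assay on cells (Leukemia cell, Homo sapiens) for cytotoxicity, with a stated time of 48 h (on this read-out lower numbers stand for stronger inhibition of growth and higher numbers for weaker inhibition of growth), compound 1 gives 2630 nM, the lowest of the two numbers. For the measured compounds named here, the only other measured member, compound 2 `COc1ccc2c(c1)/C(=C\c1c(Cl)n(Cc3cc(OC)c(OC)c(OC)c3)c3cc(C)c(OC)cc13)C(=O)N2`, differs from compound 1 in several places at once; in this assay compound 2 gives 77600 nM, a number well beyond the scatter above that of compound 1. Going by the values given here, no pair of measured compounds differs in a single place, so no single change can be read off from these two values.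

Compound 3 `COc1ccc2c(c1)/C(=C\c1c(OC)n(-c3ccccc3)c3ccccc13)C(=O)N2` is the next member to be measured. It differs from compound 1 in one place only: methoxy in place of hydrogen on an aromatic carbon. Among the compounds with values here, nothing among the measured compounds isolates this change, so the expectation rests on compound 1 alone. The step from compound 1 to compound 3 is expected to be small, a 1.2-fold higher number from compound 1 to compound 3 (0.09 log units; within the scatter), most likely none beyond the scatter, with some weight given to a weaker outcome. Compound 3 is therefore expected to give about 3200 nM in this assay, within a range from 800 nM to 13000 nM.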

Compound 3, concentration for total growth inhibition: 4470 nM
Estimate against measurement, compound 3: 1.4-fold (0.15 log units) below, within the range that was stated.
By their numbers in this assay, from the lowest: compounds 1 and 3 (each within the scatter of the next); then compound 2.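

In this assay, for the compounds shown here, methoxy in place of hydrogen on an aromatic carbon of a six-membered aromatic ring of carbon only, part of a fused or bridged system of two rings, gives a 1.7-fold higher number from compound 1 to compound 3 (0.23 log units; within the scatter) and is the first change that can be read in a single place. At this position, meta to a fused ring and para to a fused ring, methoxy therefore leaves compound 3 not separated from compound 1, a result that the two earlier compounds, differing in several places at once, could not give. No measurement at hand offers an explanation for this step.

One substituent at one position says little about the position as a whole, so a hydroxyl group, a chlorine atom, an amine or a longer alkoxy chain in the same place could give a quite different number. The several places in which compound 2 differs from compound 1 also remain unresolved, as none of those changes can yet be read on its own.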